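Para-substituted chalcones: ethyl to nitro on the styryl ring

The source may hold more compounds than are shown below. What is called first, only, known or untested is meant among the compounds shown, and "the series" means these compounds.

Measured so far:
compound 1 `CCOc1ccc(C(=O)/C=C/c2ccc(C)cc2)cc1` — 210 nM
compound 2 `CCOc1ccc(C(=O)/C=C/c2ccc(CC)cc2)cc1` — 210 nM

In an assay on isolated protein for inhibition of Amine oxidase [flavin-containing] B (Homo sapiens) (on this read-out lower numbers stand for stronger inhibition and higher numbers for weaker inhibition), compound 1 gives 210 nM and compound 2 gives 210 nM. The step of no change at the digits printed from compound 1 to compound 2 (within the scatter) shows that lengthening methyl to ethyl leaves the read-out where it was, so compound 2 stands level with compound 1 in this assay.

Compound 3 `CCOc1ccc(C(=O)/C=C/c2ccc([N+](=O)[O-])cc2)cc1` carries nitro in place of ethyl on an aromatic carbon, on an aromatic carbon of a six-membered aromatic ring of carbon only. For the measured compounds named here, no measured step exchanges an alkyl for a nitro group; the one step available, from compound 1 to compound 2, only varies chain length and gave no change. The expectation for compound 3 in this assay therefore rests on little, and a step of a 1.9-fold higher number from compound 2 to compound 3 (0.28 log units; within the scatter) is estimated, with a wide range. Compound 3 is expected to give 400 nM in this assay, between 100 nM and 2000 nM.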

Compound 3, half-maximal inhibitory concentration: 210 nM
The estimate for compound 3 lay 1.9-fold (0.28 log units) above the measured number; measured number inside the range.
By their numbers in this assay, from the lowest: compounds 1, 2 and 3 (each within the scatter of the next).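

In this assay, nitro in place of ethyl gives no change at the digits printed from compound 2 to compound 3 (within the scatter) and nitro in place of methyl gives no change at the digits printed from compound 1 to compound 3 (within the scatter) on this aromatic carbon, para to a large group. For the compounds shown here, the position, so far seen only with alkyl groups differing in chain length, now also tolerates a group of a different kind, with nitrogen, oxygen and hydrogen-bond acceptors, and the read-out stays level across all three compounds. No supporting information bears on why the read-out stays level.

As far as these compounds go, whether an amine, a carboxylic acid, a halogen such as fluorine or a longer chain such as butyl on this carbon would also leave the read-out level remains open. From the compounds shown here alone, all three compounds share the rest of the core, so it is also open whether this tolerance would persist with the ethoxy group exchanged.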